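Aryl thioether series: ester in place of fluoropropoxy

A few compounds are considered here, and "the series" means these few. Any claim that something is new, unique, unknown or untested is made for them only; others in the source may bear on it.

Compound 1 `COc1ccccc1S[C@@H](c1ccccc1)[C@@H]1CNCCO1` and compound 2 `FCCCOc1ccccc1S[C@@H](c1ccccc1)[C@@H]1CNCCO1` share a core, and the step that the two limits leave unreadable from compound 1 to compound 2 in an in vitro assay on cells (kidney) for displacement of a labelled ligand from sodium-dependent dopamine transporter (Homo sapiens) (on this read-out higher numbers stand for weaker inhibition and lower numbers for stronger inhibition), cannot be sized. In this assay compound 1 reaches only a limit, > 4000 nM. Compound 2 likewise reaches only a limit in this assay, > 9000 nM, so compound 2 stands at a limit rather than at a number. Compound 3 `COC(=O)c1ccccc1S[C@@H](c1ccccc1)[C@@H]1CNCCO1` alters compound 2 by methoxycarbonyl in place of 3-fluoropropoxy on an aromatic carbon. Going by the values given here, the single measured step is unreadable, so no step bears on this change and no direction beyond the scatter can be expected. Compound 3 is estimated at 6000 nM, between 1500 nM and 20000 nM, an expected step of an at least 1.5-fold lower number from compound 2 to compound 3 (0.17 log units; that floor lies within the scatter).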

Compound 3, inhibition constant: > 30000 nM
Compound 3: no number, only a limit; the forecaster's own chance of this, stated with the estimate: 65%; middle value at least 5.0-fold (0.69 log units) away from the limit.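

Going by these compounds alone, compound 3 reaches only a limit, > 30000 nM, and compound 1 and compound 2 also stand at limits, so no step among them can be read. The compounds shown leave open whether methoxy, 3-fluoropropoxy and methoxycarbonyl differ at all on this read-out.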